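Trimming a Methoxy Group: From Compound 2 to Compound 3

The source may report more compounds than this note shows. Statements on the series, on what has been measured and on what is new or still open speak of the compounds shown alone.

Two measured compounds share a common core and differ only in how many methoxy groups sit on one six-membered aromatic ring of carbon only. Compound 1 `COc1ccc(-c2cc(/C=C/C(=O)c3ccc(N)cc3)[nH]n2)cc1` carries a single methoxy group, while compound 2 `COc1cc(-c2cc(/C=C/C(=O)c3ccc(N)cc3)[nH]n2)cc(OC)c1OC` carries three. In a functional assay on BT-549 cells (Homo sapiens) for inhibition, read by sulforhodamine B assay, with a stated time of 48 h (a higher number here means a weaker inhibitor of growth, a lower number a stronger inhibitor of growth), compound 1 gives 1740 nM. In this assay compound 2 gives 1380 nM. Compound 2 holds the lowest of the two numbers, but its nearest neighbour, compound 1, lies within the usual scatter of it, so the two cannot be separated on this evidence.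

Compound 3 `COc1ccc(-c2cc(/C=C/C(=O)c3ccc(N)cc3)[nH]n2)cc1OC` is the intermediate case. It differs from compound 2 by hydrogen in place of methoxy on an aromatic carbon. Among the measured compounds shown here, no step between measured compounds describes this exact change, and no pattern can be claimed from two points. Because compound 1 at 1740 nM and compound 2 at 1380 nM lie so close together, the step of a 1.1-fold higher number from compound 2 to compound 3 (0.04 log units; within the scatter) is expected to be none beyond the scatter. Compound 3 is therefore estimated at 1500 nM, with a range from 700 nM to 3200 nM.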

Compound 3, concentration for 50% growth inhibition: 1500 nM
Estimate against measurement, compound 3: no gap at the digits printed; the measured number falls inside the stated range.
By their numbers in this assay, from the lowest: compounds 2, 3 and 1 (each within the scatter of the next).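

In this assay, among the compounds shown here, the step of a 1.1-fold higher number from compound 2 to compound 3 (0.04 log units; within the scatter) gives the first reading of a single change at this position, on an aromatic carbon ortho to a methoxy group and meta to a large group: with hydrogen in place of methoxy there, the number cannot be told apart from that of compound 2. The step of a 1.2-fold lower number from compound 1 to compound 3 (0.06 log units; within the scatter), with methoxy in place of hydrogen on an aromatic carbon, is also within the scatter, so compound 3 links compound 1 and compound 2 through two single changes, neither of which can be separated from repeat variation. Methoxy and hydrogen are thus not distinguished at either of the two places tested in this series, and nothing at hand bears on why the numbers lie so close together.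

The compounds shown leave open whether any group other than methoxy or hydrogen at these places, such as a fluorine atom, an amine, a carboxylic acid or a longer chain like ethoxy, would give a step beyond the scatter. They also leave open whether a change elsewhere, for instance to the amine on the other aromatic ring, would move the number further than these methoxy changes do.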